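Methyl Added to the Aryl Ring of a Thiosemicarbazide

The compounds below may be only part of what the source reports. "The series", "measured", "known", "first", "only" and "open" are said of these compounds alone.

The measured compounds so far:
compound 1, `COc1cc(C(=O)NNC(=S)Nc2csc(-c3ccc(C)cc3)c2)cc(OC)c1OC`, 42000 nM;
compound 2, `COc1ccc(C(=O)NNC(=S)Nc2csc(-c3ccc(C)cc3)c2)cc1`, 12000 nM;
compound 3, `COc1ccc(C(=O)NNC(=S)Nc2csc(-c3ccccc3)c2)cc1OC`, 22000 nM.

In a functional assay on Hs 683 cells (Homo sapiens) for inhibition, read by colorimetric assay and MTT assay, with a stated time of 72 h (on this read-out higher numbers stand for weaker inhibition and lower numbers for stronger inhibition), compound 3 gives 22000 nM, the second highest of the three numbers. Its nearest neighbour is compound 2 with 12000 nM, and the furthest is compound 1 with 42000 nM; both gaps lie within the scatter, so the three values cannot be told apart on these data.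

Compound 4, `COc1ccc(C(=O)NNC(=S)Nc2csc(-c3ccc(C)cc3)c2)cc1OC`, has not yet been measured. It differs from compound 3 in one place: methyl in place of hydrogen on an aromatic carbon. Compounds 1 and 2 already carry the 4-methylphenyl group that compound 4 acquires, and their values bracket that of compound 3 without a gap beyond the scatter, so the methyl group on this ring gives no sign of a directional effect within this set.

Among the measured compounds shown here, no step between two measured compounds that differ only here has been recorded. Compound 4 is therefore expected to land close to compound 3, with a step of a 1.1-fold lower number from compound 3 to compound 4 (0.04 log units; within the scatter) that stays within the scatter. In this assay compound 4 is estimated at 20000 nM, with a range from 8000 nM to 50000 nM.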

Compound 4, half-maximal inhibitory concentration: 39000 nM
Compound 4: the middle estimate sits 2.0-fold (0.29 log units) below what was measured; measured number inside the range.
By their numbers in this assay, from the lowest: compounds 2, 3, 4 and 1 (each within the scatter of the next, the first and the last beyond it).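

In this assay, among the compounds shown here, the step phenyl to 4-methylphenyl gives a 1.8-fold higher number from compound 3 to compound 4 (0.25 log units; within the scatter), so this is the first direct reading of methyl in place of hydrogen at this place, para to a large group, and it shows no change that can be told from the scatter. For the compounds shown here, with the 4-methylphenyl group held the same, the methoxy groups on the other aryl ring give the only step here that clears the scatter: one further methoxy group on that ring gives a 3.3-fold higher number from compound 2 to compound 4 (0.51 log units; beyond the scatter) in a modest step towards weaker inhibition. Hydrogen in place of methoxy gives a 1.1-fold lower number from compound 1 to compound 4 (0.03 log units; within the scatter) on the same ring, so compound 1 and compound 4 cannot be told apart, and among these steps the methoxy change counts for more than the methyl change.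

On these data alone, whether a different group at the methyl place, such as an amine, a carboxylic acid or a longer chain, would move the number beyond the scatter stays open. What lies behind these steps also stays open, as no measurement shown here bears on it.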